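The source may hold more compounds than are shown below. What is called first, only, known or untested is meant among the compounds shown, and "the series" means these compounds.

In a physicochemical assay for lipophilicity, read by HPLC, at pH 7.5 (on this read-out lower numbers stand for lower lipophilicity and higher numbers for higher lipophilicity), compound 3 `CC[C@@H](Nc1c(C#N)c(-c2ccc(-c3ccc(OC)cc3)cc2)nc2cnccc12)C(N)=O` reads 2.7. It stands level with compound 1 `CC[C@@H](Nc1c(C#N)c(-c2ccc(-c3ccccc3F)cc2)nc2cnccc12)C(N)=O` at 2.7, and both lie under compound 2 `CC[C@@H](Nc1c(C#N)c(-c2ccc(-c3cccc(Cl)c3F)cc2)nc2cnccc12)C(N)=O` at 3.1. Compound 4 `CC[C@@H](Nc1c(C#N)c(-c2ccc(-c3cccnc3C)cc2)nc2cnccc12)C(N)=O` differs from compound 3 in one place: 2-methylpyridin-3-yl in place of 4-methoxyphenyl on an aromatic carbon. Three measured steps give a sense of scale. Exchanging one ring of carbon only for another gave no change at the digits printed from compound 1 to compound 3 (within the scatter), while the other two steps were modest, a number 0.40 log units higher from compound 1 to compound 2 (beyond the scatter) and a number 0.40 log units lower from compound 2 to compound 3 (beyond the scatter). None of these steps brings in a ring with a hetero atom, so they guide the size only loosely. A modest fall is expected, a number 0.50 log units lower from compound 3 to compound 4 (beyond the scatter). The estimated value for compound 4 is 2.2, with an expected range from 1.8 to 2.6.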

Compound 4, distribution coefficient: 1.9
For compound 4 the middle estimate is 0.30 log units above the measured one, within the range that was stated.
By their numbers in this assay, from the lowest: compound 4; then compounds 1 and 3 (each within the scatter of the next); then compound 2.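

Among the compounds shown, 2-methylpyridin-3-yl is the only ring with a hetero atom at this place, para to a large group, and in this assay it gives the lowest number: a number 0.80 log units lower from compound 3 to compound 4 (beyond the scatter), a number 0.80 log units lower from compound 1 to compound 4 (beyond the scatter) and a number 1.20 log units lower from compound 2 to compound 4 (beyond the scatter). Among the compounds shown here, no step among the earlier compounds, all with rings of carbon only, was as large. Nothing shown explains why the number falls.

Compound 4 brings in the ring nitrogen and the methyl together, so a plain pyridin-3-yl would be needed to separate their shares. On these data alone, how a ring bearing an amine or a carboxylic acid would read here also stays open.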